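Swapping 2-hydroxyphenyl for 3-hydroxyphenyl in compound 3

The source may report more compounds than this note shows. Statements on the series, on what has been measured and on what is new or still open speak of the compounds shown alone.

Measured so far in an ADME assay on PC-12 cells (Rattus norvegicus) for cytotoxicity, read by WST assay, with a stated time of 24 h; a higher number here means that more compound is tolerated, a lower number that less compound is tolerated:
- compound 1 `O=C(/C=C/c1ccccc1O)CC(=O)/C=C/c1cc(O)ccc1O`: 38000 nM
- compound 2 `O=C(/C=C/c1cccc(O)c1)CC(=O)/C=C/c1cc(O)ccc1O`: 15000 nM
- compound 3 `O=C(/C=C/c1ccccc1O)CC(=O)c1ccc(O)c(O)c1`: > 90000 nM (a limit of the assay, not a number)

Compound 3 has no exact value, only (the limit of > 90000 nM in this assay, at which 1 of the 3 values shown sits). Compound 4 `O=C(/C=C/c1cccc(O)c1)CC(=O)c1ccc(O)c(O)c1` differs from it by one swap: 3-hydroxyphenyl in place of 2-hydroxyphenyl on a double-bonded chain carbon bound to a double-bonded chain carbon. The same swap has been measured once, as a 2.5-fold lower number from compound 1 to compound 2 (0.40 log units; beyond the scatter), a modest step beyond the usual scatter, though the rest of those two molecules differs from compound 3. A similar modest drop to a lower number is therefore expected in this assay, meaning less compound is tolerated. The expected change is an at least 1.8-fold lower number from compound 3 to compound 4 (0.25 log units; that floor lies within the scatter). For compound 4 the estimate is 50000 nM, expected within 20000 nM to 90000 nM.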

Compound 4, half-maximal cytotoxic concentration in the PC-12 assay: > 100000 nM
Compound 4: a limit, no number (the forecaster's own chance of this, stated with the estimate: 35%); middle value at least 2.0-fold (0.30 log units) from the limit.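

In the PC-12 assay, compound 3 gives > 90000 nM, which is a limit of the assay, not a number. In the same assay, compound 4 gives > 100000 nM, which is also a limit, not a number. For the compounds shown here, no step between them can be read. Going by these compounds, whether 3-hydroxyphenyl in place of 2-hydroxyphenyl changes tolerance in this pair remains open. In a physicochemical assay for solubility, using the shake flask method, with a stated time of 12 h (a lower number here means a less soluble compound, a higher number a more soluble compound), compound 3 gives 77000 nM and compound 4 gives 25000 nM.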